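The compounds below may be only part of what the source reports. "The series", "measured", "known", "first", "only" and "open" are said of these compounds alone.

Measured compounds in a functional assay on A549 cells (Homo sapiens) for inhibition, read by CCK-8 assay, with a stated time of 48 h; a higher number here means a weaker inhibitor, a lower number a stronger inhibitor:
- compound 1 `COc1cc(-c2ccnc3cc(-c4ccccc4)nn23)cc(OC)c1OC` gives 208 nM
- compound 2 `COc1cc(-c2ccnc3cc(-c4cn(C(=O)OC(C)(C)C)c5ccccc45)nn23)cc(OC)c1OC` gives 2070 nM

Of the two numbers, compound 1 has the lower one; compound 2 sits at a clearly higher number, a gap beyond the usual scatter, so compound 1 is the stronger inhibitor of the pair in this assay. The unmeasured compound 3 `COc1cc(-c2ccnc3cc(-c4ccc5cnn(C)c5c4)nn23)cc(OC)c1OC` keeps the shared core of compound 1 and differs from it in one place: 1-methyl-1H-indazol-6-yl in place of phenyl on an aromatic carbon. Within the data shown here, no step between measured compounds isolates this exact change, so the expectation rests on the two numbers alone. Among the measured compounds shown here, both measured compounds carry an aromatic group at this position, and the only other group tried there, in compound 2, gave a weaker inhibitor. Compound 3 is therefore expected to fall somewhat above compound 1, with a step of a 2.2-fold higher number from compound 1 to compound 3 (0.34 log units; beyond the scatter) in this assay that is modest and may not exceed the scatter. The estimate for compound 3 is 450 nM, with a range from 130 nM to 1600 nM.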

Compound 3, half-maximal inhibitory concentration: 233 nM
Beside the measured number, compound 3's estimate is 1.9-fold (0.29 log units) above it; measured number inside the range.
By their numbers in this assay, from the lowest: compounds 1 and 3 (each within the scatter of the next); then compound 2.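

In this assay, 1-methyl-1H-indazol-6-yl in place of phenyl gives a 1.1-fold higher number from compound 1 to compound 3 (0.05 log units; within the scatter), so this position accepts a group of two aromatic rings, with two hydrogen-bond acceptors where phenyl has none, and the number stays within the scatter. Among these compounds, compound 2, at 2070 nM, had been the only other group seen here, and compound 3 shows that its higher number does not hold for every larger aromatic group at this position. Nothing available explains why phenyl and 1-methyl-1H-indazol-6-yl read alike in this assay.

The compounds shown leave open how an aromatic group carrying an amine or a carboxylic acid would read at this position. They also leave open whether the methyl on the indazole matters, which a comparison with the parent 1H-indazol-6-yl group would address.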